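The source may report more compounds than this note shows. Statements on the series, on what has been measured and on what is new or still open speak of the compounds shown alone.

Compound 2 `CC(C)C[C@H](N)c1cc(C(F)(F)F)ccc1N1CCN(C(=O)CCC(N)=O)CC1` belongs to a small set of three measured analogues that share one core. In an assay on HEK293 cells for displacement of a labelled ligand from Melanocortin receptor 4 (Homo sapiens) (a higher number here means a weaker inhibitor, a lower number a stronger inhibitor), compound 2 reaches only the limit of the assay, > 10000 nM, and no number is reported. Compound 3 `CC(C)C[C@H](N)c1cc(C(F)(F)F)ccc1N1CCN(C(=O)CC(C)C(=O)c2ccc(Cl)cc2)CC1` gives 1100 nM in this assay, and compound 1 `CC(C)C[C@H](N)c1cc(Cl)ccc1N1CCN(C(=O)C(C)Cc2ccc(Cl)cc2)CC1` gives 67 nM. Compound 2 thus stands at the weak end of the values shown, at the limit of > 10000 nM in this assay, at which 1 of the 3 values shown sits. Going by the values given here, the one measured step starting from compound 2 is an at least 9.0-fold lower number from compound 2 to compound 3 (0.95 log units; beyond the scatter), where the carbamoyl end of the chain is exchanged for a chain bearing a chlorophenyl carbonyl group. Compound 4 `CC(C)C[C@H](N)c1cc(C(F)(F)F)ccc1N1CCN(C(=O)CCNC2CCCCC2)CC1` differs from compound 2 in the same region, by cyclohexylamino in place of carbamoyl on a saturated chain carbon, two bonds along the chain from a carbonyl carbon. Since that exchange also removes the carbamoyl group, compound 4 is expected to move in the same direction as compound 3, that is toward a lower number, though whether it clears the limit is uncertain. Compound 4 is therefore estimated at 3000 nM in this assay, with a range from 500 nM to 15000 nM. That would be an expected step of an at least 3.3-fold lower number from compound 2 to compound 4 (0.52 log units; beyond the scatter).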

Compound 4, inhibition constant: 4800 nM
Estimate against measurement, compound 4: 1.6-fold (0.20 log units) below, within the range that was stated.
By their numbers in this assay, from the lowest: compound 1; then compound 3; then compound 4. At a limit, above all of these: compound 2.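

In this assay, the exchange of carbamoyl for cyclohexylamino on this saturated chain carbon, two bonds along the chain from a carbonyl carbon, gives an at least 2.0-fold lower number from compound 2 to compound 4 (0.31 log units; beyond the scatter), so a second, quite different replacement also yields a measurable number. Going by these compounds, the true size of this step stays unknown, because compound 2 has only a limit: the limit of > 10000 nM in this assay, at which 1 of the 4 values shown sits. The two replacements are not equal, with a 4.4-fold higher number from compound 3 to compound 4 (0.64 log units; beyond the scatter), so what enters on the chain matters and not only the loss of carbamoyl.

The compounds shown do not separate the ring of cyclohexylamino from its nitrogen, a question that a plain amine on the same chain carbon or a longer chain carrying the cyclohexylamino group would address. Compound 1 differs from compound 4 in more than one place, so it gives no reading of this change.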